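Swapping a benzyl for an aniline on a shared pyrimidine core

The source may report more compounds than this note shows. Statements on the series, on what has been measured and on what is new or still open speak of the compounds shown alone.

Of the compounds shown here, two have been measured so far in a functional assay on Jurkat cells (Homo sapiens) for inhibition, read by CCK-8 assay, with a stated time of 48 h; a lower number here means a stronger inhibitor of growth, a higher number a weaker inhibitor of growth. Compound 1, `Cc1ccccc1Nc1nc(Nc2cccnc2)ncc1Cl`, gives 38600 nM. Compound 2, `Cc1ccc(CNc2nc(Nc3ccc(N4CCN(C)CC4)cn3)ncc2Cl)cc1`, gives 12700 nM. On these two numbers compound 2 stands lowest, meaning the stronger inhibitor of growth, and the gap between it and compound 1 is beyond the usual scatter. The two structures differ in several places at once. Nothing more than that comparison of values can be drawn from them.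

Compound 3, `CC(C)c1ccc(Nc2nc(Nc3ccc(N4CCN(C)CC4)cn3)ncc2Cl)cc1`, is not yet measured. It keeps the rest of compound 2 unchanged and differs in one place: 4-isopropylphenyl in place of 4-methylbenzyl on a nitrogen on an aromatic ring. The change therefore removes the single linking carbon that held the ring away from the nitrogen and puts a larger alkyl group on that ring.

Going by the values given here, no measured pair shows this exact move, so the expectation rests on compound 2 alone. A modest gain is expected, with the step of a 1.6-fold lower number from compound 2 to compound 3 (0.20 log units; within the scatter) judged to lie only slightly beyond the scatter. Compound 3 is estimated at 8000 nM, within a range from 2500 nM to 25000 nM.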

Compound 3, concentration for 50% growth inhibition: 7530 nM
Beside the measured number, compound 3's estimate is 1.1-fold (0.03 log units) above it; measured number inside the range.
By their numbers in this assay, from the lowest: compounds 3 and 2 (each within the scatter of the next); then compound 1.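

Going by these compounds alone, for the first time, two compounds that differ in only one place can be compared directly. In this assay, the change gives a 1.7-fold lower number from compound 2 to compound 3 (0.23 log units; within the scatter), so the numbers do not separate a 4-methylbenzyl from a 4-isopropylphenyl on this nitrogen. This position therefore accepts both groups in this assay, even though the change removes the single linking carbon and puts a larger alkyl group on the ring, and neither compound can be ranked above the other. No measurement offered here explains why the two compounds cannot be told apart.

The two parts of the change remain tangled, since the linking carbon and the alkyl group differ together, and only a pair such as 4-methylphenyl and 4-isopropylbenzyl on the same nitrogen could show what each contributes alone. Going by these compounds, it also remains open whether a quite different group on that ring, such as an amine or a carboxylic acid in place of the isopropyl, would move the number beyond the scatter.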